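A few compounds are considered here, and "the series" means these few. Any claim that something is new, unique, unknown or untested is made for them only; others in the source may bear on it.

Measured compounds in an assay (strain Sprague-Dawley) for displacement of a labelled ligand from metabotropic glutamate receptor 5 (Rattus norvegicus), with a stated time of 60 min; a lower number here means a stronger inhibitor, a higher number a weaker inhibitor:
compound 1 `O=S(=O)(c1ccc(F)c(F)c1)c1cnc2cc(F)ccc2c1-c1ccc(Cl)cc1` gives 17.1 nM
compound 2 `O=S(=O)(c1ccc(F)cc1)c1cnc2ccc(F)cc2c1-c1ccc(Cl)cc1` gives 180 nM
compound 3 `O=S(=O)(c1cc(F)cc(F)c1)c1cnc2cc(F)ccc2c1-c1cccc(F)c1` gives 32.6 nM

Compound 3 stands second highest of the three numbers in this assay. Its nearest neighbour is compound 1, whose number lies within the scatter of it, so no order between them is claimed; compound 2 sits beyond the scatter with the higher number.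

Compound 4 `O=S(=O)(c1cc(Cl)cc(Cl)c1)c1cnc2cc(F)ccc2c1-c1cccc(F)c1` has not yet been measured. It differs from compound 3 in one place: 3,5-dichlorophenyl in place of 3,5-difluorophenyl on a sulfonyl sulfur. Among the compounds with values here, no step between measured compounds bears on this change, so nothing measured here points in either direction. The expected step, a 1.1-fold lower number from compound 3 to compound 4 (0.04 log units; within the scatter), is small, likely staying within the scatter. Compound 4 is expected to give 30 nM in this assay, with a range from 10 nM to 100 nM.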

Compound 4, inhibition constant: 10.7 nM
Compound 4: the middle estimate sits 2.8-fold (0.45 log units) above what was measured, and the stated range covers the measured number.
By their numbers in this assay, from the lowest: compounds 4, 1 and 3 (each within the scatter of the next, the first and the last beyond it); then compound 2.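

In this assay, within the data shown here, this sulfonyl aryl position is sensitive to the halogen it carries: 3,5-dichlorophenyl in place of 3,5-difluorophenyl gives a 3.0-fold lower number from compound 3 to compound 4 (0.48 log units; beyond the scatter) as the only single-place step. Compounds 1, 2 and 3 differ from each other in more than one place, so they could not isolate this position. Nothing available accounts for the step.

As far as these compounds go, whether the step holds on other cores of the series remains open. So does the outcome with methoxy or nitrile in place of the chlorines on this ring.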